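Swapping the aryl group on the five-membered ring: compound 3

This account rests on a few compounds, and the source may have more. Where it says the series, first, only, none or still open, it means among the compounds named here.

Of the compounds shown here, two sharing one core have been tested in a functional assay on HCT-116 cells (Homo sapiens) for inhibition, read by MTT assay, with a stated time of 24 h, tested at 10 uM; on this read-out higher numbers stand for more inhibition of growth at the one concentration tested and lower numbers for less inhibition of growth. Compound 1 `CS(=O)(=O)c1ccc(-c2cnc3[nH]cc(-c4nnc(-c5ccncc5)o4)c(=O)c3c2)cc1` gives 7.83% in this assay. Compound 2 `CS(=O)(=O)c1ccc(-c2cnc3[nH]cc(-c4nnc(-c5ccc(Cl)cc5)o4)c(=O)c3c2)cc1` gives 17% in this assay, the higher of the two numbers, yet the step of a number 9.2 percentage points higher from compound 1 to compound 2 (within the scatter) is within the scatter, so the two compounds cannot be told apart. Compound 3 `CS(=O)(=O)c1ccc(-c2cnc3[nH]cc(-c4nnc(-c5cccnc5)o4)c(=O)c3c2)cc1` has not been measured. It differs from compound 2 by pyridin-3-yl in place of 4-chlorophenyl on an aromatic carbon. Going by the values given here, the only step that bears on this change is the one from compound 1 to compound 2, which exchanged one six-membered ring for another at the same place and produced no difference beyond the scatter. The return to a nitrogen-containing ring is therefore expected to give a step of a number 6 percentage points lower from compound 2 to compound 3 (within the scatter), not beyond the scatter. Compound 3 is estimated at 11%, with a range from 0% to 24%.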

Compound 3, percent growth inhibition at one concentration: 14.7%
Estimate against measurement, compound 3: 3.7 percentage points below; the range from low to high includes it.
By their numbers in this assay, from the lowest: compounds 1, 3 and 2 (each within the scatter of the next).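

In this assay, pyridin-3-yl in place of 4-chlorophenyl gives a number 2.3 percentage points lower from compound 2 to compound 3 (within the scatter), and pyridin-3-yl in place of pyridin-4-yl gives a number 6.9 percentage points higher from compound 1 to compound 3 (within the scatter). The second step is new information: shifting the nitrogen within the pyridine ring makes no difference that can be told from the scatter, so on this carbon of the five-membered ring the three six-membered aromatic rings cannot be told apart, with or without a ring nitrogen. Nothing available here explains why these three rings read alike.

Still open, going by these compounds, is whether a pyridin-2-yl ring on the same carbon would also stay within the scatter. On these data alone, it is also open whether a group of a different kind there, such as an amine, a carboxylic acid or a longer alkyl chain, would move the number beyond the scatter.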